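The compounds below may be only part of what the source reports. "The series", "measured", "known", "first", "only" and "open" are said of these compounds alone.

In a functional assay on NCI-H23 cells (Homo sapiens) for antiproliferative activity, read by sulforhodamine B assay, with a stated time of 48 h (a lower number here means a stronger inhibitor of growth, a higher number a weaker inhibitor of growth), compound 2 `COc1ccc(OC)c(/C=C/C(=O)N/N=C/c2ccc(Cl)cc2)c1` gives 148 nM, the lowest number among the two compounds measured here. Compound 1 `COc1ccc(OC)c(/C=C/c2nnc(Nc3ccc(Cl)cc3)o2)c1`, built around a different core, gives 21700 nM in this assay, a far higher number, and that gap lies well beyond the usual scatter. Compound 3 `COc1ccc(OC)c(/C=C/C(=O)N/N=C/c2ccccc2)c1` differs from compound 2 in one place: hydrogen in place of chloro on an aromatic carbon. Within the data shown here, no measured pair shows this change on its own, so its effect is not known from these data. The expected step is a 2.0-fold higher number from compound 2 to compound 3 (0.31 log units; beyond the scatter), at most a small weakening. Compound 3 is therefore expected to give about 300 nM, within 100 nM to 1000 nM.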

Compound 3, concentration for 50% growth inhibition: 5400 nM
Estimate against measurement, compound 3: 18-fold (1.26 log units) below, and the stated range ends below it.
By their numbers in this assay, from the lowest: compound 2; then compound 3; then compound 1.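

Replacing the chloro group, para to a large group on the aromatic ring, with hydrogen gives a 36-fold higher number from compound 2 to compound 3 (1.56 log units; beyond the scatter) in this assay, so this single atom matters greatly here. Among these compounds, this is the first measured pair that differs in one place, and it shows that this position is far from indifferent to what sits on it. Nothing measured here explains the size of this step. Whether chlorine itself is needed stays open, since the compounds shown carry no bromo, methyl or amine group at this position.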